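The source may hold more compounds than are shown below. What is called first, only, known or untested is meant among the compounds shown, and "the series" means these compounds.

Compound 3 `CN(C(=O)NC(=O)c1ccc(F)c(F)c1)c1nc(C(F)(F)F)c(C(=O)N/N=C/c2cccc(C(F)(F)F)c2)s1` is tested in a functional assay on MCF7 cells (Homo sapiens) for inhibition, read by MTT assay, with a stated time of 72 h (a lower number here means a stronger inhibitor, a higher number a weaker inhibitor), and gives 4.15 ug/mL, the lowest of the three numbers, though within the scatter of compound 2 `CN(C(=O)NC(=O)c1cccc([N+](=O)[O-])c1)c1nc(C(F)(F)F)c(C(=O)N/N=C/c2ccccc2C(F)(F)F)s1` at 4.73 ug/mL and of compound 1 `CN(C(=O)NC(=O)c1cccc(C(F)(F)F)c1)c1nc(C(F)(F)F)c(C(=O)N/N=C/c2ccccc2C(F)(F)F)s1` at 7.69 ug/mL. Among the compounds with values here, the only measured step, a 1.6-fold lower number from compound 1 to compound 2 (0.21 log units; within the scatter), concerns a different part of the core and does not bear on the present change. Compound 4 `CN(C(=O)NC(=O)c1ccc(F)c(F)c1)c1nc(C(F)(F)F)c(C(=O)N/N=C/c2ccccc2C(F)(F)F)s1` differs from compound 3 by 2-(trifluoromethyl)phenyl in place of 3-(trifluoromethyl)phenyl on a carbon with a double bond to nitrogen. Within the data shown here, compound 1 and compound 2 already carry the 2-(trifluoromethyl)phenyl, but they differ from compound 3 in a second place as well, so no single step isolates this move. No change beyond the scatter in this assay is therefore expected; the estimate for compound 4 is 4.5 ug/mL with a range of 2.2 ug/mL to 9 ug/mL, meaning an expected step of a 1.1-fold higher number from compound 3 to compound 4 (0.04 log units; within the scatter).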

Compound 4, half-maximal inhibitory concentration: 8.21 ug/mL
Compound 4: the middle estimate sits 1.8-fold (0.26 log units) below what was measured; the range from low to high includes it.
By their numbers in this assay, from the lowest: compounds 3, 2, 1 and 4 (each within the scatter of the next).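

In this assay, within the data shown here, 2-(trifluoromethyl)phenyl in place of 3-(trifluoromethyl)phenyl on a carbon with a double bond to nitrogen gives a 2.0-fold higher number from compound 3 to compound 4 (0.30 log units; within the scatter) as the first direct reading at this position, so this exchange stays within the scatter. With 2-(trifluoromethyl)phenyl held, 3,4-difluorophenyl on a carbonyl carbon gives a 1.7-fold higher number from compound 2 to compound 4 (0.24 log units; within the scatter) when it replaces 3-nitrophenyl and a 1.1-fold higher number from compound 1 to compound 4 (0.03 log units; within the scatter) when it replaces 3-(trifluoromethyl)phenyl, so neither exchange separates these compounds. No available measurement offers an explanation for these steps. Open, as far as these compounds go, is whether an amine or a carboxylic acid in place of trifluoromethyl on that phenyl would move the number beyond the scatter.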